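The source may report more compounds than this note shows. Statements on the series, on what has been measured and on what is new or still open speak of the compounds shown alone.

Measured compounds in an in vitro functional assay on cells for antagonist activity at metabotropic glutamate receptor 5 (Homo sapiens), read by FLIPR and calcium flux; on this read-out higher numbers stand for weaker inhibition and lower numbers for stronger inhibition:
Compound 1 `Cc1nc2c(cnn2CC2CCCCC2)c(=O)n1-c1ccc(Cl)cc1` – compound 1 gives > 100000 nM, a limit of the assay.
Compound 2 `Cc1nc2c(cnn2-c2cccc(Cl)c2)c(=O)n1-c1ccc(Cl)cc1` – compound 2 gives > 100000 nM, also a limit.
Compound 3 `Cc1nc2c(cnn2-c2ccc(S(N)(=O)=O)cc2)c(=O)n1-c1ccc(Cl)cc1` – compound 3 gives > 100000 nM, again a limit.

Compound 3 thus stands where every measured member of the series stands: at the limit, with no number read. Going by the values given here, the only one-place step among the measured compounds, a step that the two limits leave unreadable from compound 1 to compound 2, cannot be read for the same reason, as both ends of it are limits. All values shown sit on one line, (the limit of > 100000 nM in this assay, at which 3 of the 3 values shown sit).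

Compound 4 `Cc1nc2c(cnn2-c2ccc(Cl)cc2)c(=O)n1-c1ccc(Cl)cc1` differs from compound 3 by chloro in place of sulfamoyl on an aromatic carbon. Among the compounds with values here, no measured step touches this position, and nothing in the measured set gives a reading of how this change moves the assay value. What the three measured compounds do show is that none of the variations tried so far has brought a compound below the limit.

The step from compound 3 to compound 4 is therefore expected to be a number no higher from compound 3 to compound 4 (the limit leaves the size open), with no direction beyond the scatter. Compound 4 is estimated at 100000 nM, range 30000 nM to 300000 nM, most likely reported again only as a limit.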

Compound 4, half-maximal inhibitory concentration: > 100000 nM
Compound 4 ended at the assay's limit (the forecaster's own chance of this, stated with the estimate: 80%); the middle value lies on the limit itself.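

Compound 4 sits at the same limit as compound 1, compound 2 and compound 3, so none of the steps from these three to compound 4 can be read: the limit of > 100000 nM in this assay, at which 4 of the 4 values shown sit.

The compounds shown leave open whether any variation on the shared core gives a readable value.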